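The source may report more compounds than this note shows. Statements on the series, on what has been measured and on what is new or still open speak of the compounds shown alone.

The account follows two compounds that share a single core, and compound 3, which is built from compound 1. Compound 1 `NC(=O)c1ccc(C(=O)NCCCN2CCN(CCCNc3ccnc4cc(Cl)ccc34)CC2)cc1` and compound 2 `CCOc1ccc(C(=O)NCCCN2CCN(CCCNc3ccnc4cc(Cl)ccc34)CC2)cc1` differ only in the group on the carbonyl carbon. In an ADME assay on L6 cells (Rattus norvegicus) for cytotoxicity (a lower number here means a stronger inhibitor, a higher number a weaker inhibitor), compound 2 gives 5300 nM. Among the measured compounds shown here, compound 1 stands with no single number in this assay, its result being "not determined" (no result reported), so no step between the two measured compounds can be drawn. Compound 3 `O=C(CCCCc1ccccc1)NCCCN1CCN(CCCNc2ccnc3cc(Cl)ccc23)CC1` is reached from compound 1 by one change: 4-phenylbutyl in place of 4-carbamoylphenyl on a carbonyl carbon. No measured step in this assay is available to size that change, so the expectation rests on the one number shown, that of compound 2. Compound 3 is expected to move, if at all, toward a somewhat lower number than compound 2, by a step that may not exceed the usual scatter. Compound 3 is therefore estimated at 3000 nM, within a range from 800 nM to 12000 nM.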

Compound 3, half-maximal inhibitory concentration: 9400 nM
The estimate for compound 3 lay 3.1-fold (0.50 log units) below the measured number; the range from low to high includes it.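

In this assay the change reads as a 1.8-fold higher number from compound 2 to compound 3 (0.25 log units; within the scatter), so on this carbonyl carbon the 4-phenylbutyl and 4-ethoxyphenyl groups cannot be told apart. Among the compounds shown here, this is the first measured step at this position, and it shows that replacing the 4-ethoxyphenyl group with the 4-phenylbutyl group gives no difference beyond the scatter. Nothing measured here offers an explanation for this result.

On these data alone, compound 1 has no single number, so the step from it to compound 3 cannot be read, and it remains open how the 4-carbamoylphenyl group compares with the other two groups. Also open, as far as these compounds go, is how a group carrying a carboxylic acid or an amine, or a longer chain than 4-phenylbutyl, would read on the same carbonyl carbon.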